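Nitro Substitution on Two Diaryl Ether Cores

A few compounds are considered here, and "the series" means these few. Any claim that something is new, unique, unknown or untested is made for them only; others in the source may bear on it.

Compound 1 `CNC(=O)c1cc(Oc2ccc(NS(=O)(=O)c3ccccc3)cc2)ccn1` and compound 2 `CNC(=O)c1cc(Oc2ccc(NS(=O)(=O)c3ccc([N+](=O)[O-])cc3)cc2)ccn1` share one core; compound 3 `O=C(Nc1ccc(Oc2ccnc3ccccc23)cc1)c1cc(C(F)(F)F)ccc1F` and compound 4 `O=C(Nc1ccc(Oc2ccnc3c([N+](=O)[O-])cccc23)cc1)c1cc(C(F)(F)F)ccc1F` share another. In a functional assay on PLC-PRF-5 cells (Homo sapiens) for inhibition (a higher number here means a weaker inhibitor, a lower number a stronger inhibitor), compound 1 gives only a limit, > 40000 nM. Compound 2 likewise gives only a limit in this assay, > 40000 nM. The step that the two limits leave unreadable from compound 1 to compound 2 is therefore not readable, because of the limit of > 40000 nM in this assay, at which 2 of the 3 values shown sit. The change there is nitro in place of hydrogen on an aromatic carbon. In this assay, among the measured compounds shown here, compound 3 gives 21100 nM, the only number among the three measured compounds. The difference between the core of compound 1 and the core of compound 3 is not broken down here. Compound 4 carries the same kind of change as compound 2, namely (nitro in place of hydrogen on an aromatic carbon); around the place it differs, since in compound 4 the carbon is part of a fused or bridged system of two rings, ortho to a fused ring and meta to a fused ring, whereas in compound 2 it is para to a large group. The measured pair gives no readable size, so the expected step of a 1.1-fold lower number from compound 3 to compound 4 (0.02 log units; within the scatter) is taken as small. That expectation rests on compound 3 with 21100 nM alone. Compound 4 is expected to give about 20000 nM in this assay, between 6000 nM and 60000 nM.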

Compound 4, half-maximal inhibitory concentration: > 40000 nM
Compound 4 gave a limit, no number (the forecaster's own chance of this, stated with the estimate: 35%); middle value at least 2.0-fold (0.30 log units) away from the limit.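

In this assay compound 4 gives only a limit, > 40000 nM, and not a number. From the compounds shown here alone, on the core of compound 3, nitro in place of hydrogen on an aromatic carbon therefore reads as an at least 1.8-fold higher number from compound 3 to compound 4 (0.27 log units; that floor lies within the scatter), so the true size stays unknown and the readable floor alone does not show a change beyond the scatter. Whether the step carries over from one core to the other cannot be judged, because the step from compound 1 to compound 2 cannot be read and gives nothing to compare: the limit of > 40000 nM in this assay, at which 3 of the 4 values shown sit.

Open, going by these compounds, is whether a compound on the core of compound 1 with a number in this assay would make the effect of nitro readable on that core. Also open, on these data alone, is how an amine or a carboxylic acid in place of the nitro, on the same aromatic carbon, would read against compound 3 at 21100 nM.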